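Butynyl amines: imidazolyl to dimethylamino on two cores

A few compounds are considered here, and "the series" means these few. Any claim that something is new, unique, unknown or untested is made for them only; others in the source may bear on it.

Compound 1 `COC(=O)N(C)CC#CCn1ccnc1` gives 4.5 mg/kg in a functional assay on the whole organism for agonist activity, with Mus musculus as the target; a lower number here means that less compound is needed, a higher number that more compound is needed for the effect. Compound 2 `COC(=O)N(C)CC#CCN(C)C` carries dimethylamino in place of 1H-imidazol-1-yl on a saturated chain carbon bound to a triple-bonded carbon; in this assay compound 2 gives 9.7 mg/kg, a step of a 2.2-fold higher number from compound 1 to compound 2 (0.33 log units; beyond the scatter). Compound 3 `O=C1NCCN1CC#CCn1ccnc1` gives 30 mg/kg in this assay, the highest of the three numbers, with the value of compound 2 and the value of compound 1 both lying below it by more than the usual scatter. The difference between the core of compound 3 and the core of compound 1 is not broken down here.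

Compound 4 `CN(C)CC#CCN1CCNC1=O` is not yet measured. Relative to compound 3 it carries dimethylamino in place of 1H-imidazol-1-yl on a saturated chain carbon bound to a triple-bonded carbon. Among the compounds with values here, this is the same change as the one from compound 1 to compound 2, at the same place on the chain. Within the data shown here, the expected step is a 2.2-fold higher number from compound 3 to compound 4 (0.34 log units; beyond the scatter), which rests on the single earlier instance of this change, the step of a 2.2-fold higher number from compound 1 to compound 2 (0.33 log units; beyond the scatter), transferred to the core of compound 3. Compound 4 is therefore estimated at 65 mg/kg in this assay, with a likely range from 30 mg/kg to 140 mg/kg; the range is set wide since the change is seen only once and on a different core.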

Compound 4, dose for half-maximal effect: 9.7 mg/kg
Compound 4: middle estimate off by 6.7-fold (0.83 log units), on the high side; the whole stated range lies above it.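

In this assay the same exchange of 1H-imidazol-1-yl for dimethylamino gives a 3.1-fold lower number from compound 3 to compound 4 (0.49 log units; beyond the scatter) and so runs opposite in direction to the earlier step on the core of compound 1. The two instances do not agree: the same change on two cores in this assay, a 2.2-fold higher number (0.33 log units; beyond the scatter) from compound 1 to compound 2 and a 3.1-fold lower number (0.49 log units; beyond the scatter) from compound 3 to compound 4, 6.7-fold (0.82 log units) apart, beyond the scatter of two such steps

In this series, then, a step read on one core does not carry over to the other, not even in its direction, although the data do not show which feature of the two cores goes with the reversal, and two pairs cannot say which direction a further core would follow.

The compounds shown leave open whether another amine in the same place, such as diethylamino or pyrrolidin-1-yl, would follow the step to compound 2 or the step to compound 4. Also open, going by these compounds, is whether the reversal persists with a longer chain in place of the butynyl link shared by all four compounds.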